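Unbound fraction in the spiro series: pyridazin-3-yl swap

A few compounds are considered here, and "the series" means these few. Any claim that something is new, unique, unknown or untested is made for them only; others in the source may bear on it.

Measured so far in an ADME assay on brain (Rattus norvegicus) for protein binding; a higher number here means a larger unbound share of the compound, a lower number a smaller unbound share:
- compound 1 `Cc1ncccc1N1C[C@]2(CC[C@@H](CNc3cnn(-c4ccccc4F)c3)CC2)OC1=O` gives "not determined" (no result reported)
- compound 2 `O=C1O[C@]2(CC[C@H](CNc3ccc(-c4cc(F)cc(F)c4)nn3)CC2)CN1c1cccnn1` gives 0.016

Going by these compounds, compound 1 has no number in this assay, so its standing stays open. Compound 3 `O=C1O[C@]2(CC[C@H](CNc3cnn(-c4ccccc4F)c3)CC2)CN1c1cccnn1` carries pyridazin-3-yl in place of 2-methylpyridin-3-yl on an amide-type nitrogen in a ring as its change from compound 1. With no measured starting point, the size and direction of this step cannot be read from the data. Within the data shown here, the only anchor is compound 2 at 0.016 and no difference beyond the scatter from that value is expected. For compound 3 the unbound fraction is estimated at 0.025 within a range of 0.01 to 0.06 as the expected outcome.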

Compound 3, unbound fraction: 0.031
Beside the measured number, compound 3's estimate is 1.2-fold (0.09 log units) below it; the range from low to high includes it.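

Among these compounds, compound 1 gives "not determined" (no result reported) in this assay and so no step to compound 3 can be read. The compounds shown leave open what replacing 2-methylpyridin-3-yl with pyridazin-3-yl does to the unbound fraction. No supporting data bear on this result.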